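The source may report more compounds than this note shows. Statements on the series, on what has been measured and on what is new or still open speak of the compounds shown alone.

The measured compounds are: compound 1 `Nc1nc(Cl)c2ncn(Cc3ccc(CCl)cc3)c2n1`, which in a functional assay on BT-549 cells (Homo sapiens) for cytotoxicity, read by sulforhodamine B assay, with a stated time of 48 h (a lower number here means a stronger inhibitor of growth, a higher number a weaker inhibitor of growth), gives 6920 nM; compound 2 `ClCc1cccc(Cn2cnc3c(Cl)nc(Cl)nc32)c1`, which gives 1690 nM; and compound 3 `ClCc1ccc(Cn2cnc3c(Cl)nc(Cl)nc32)cc1`, which gives 15900 nM.

Of these three, compound 2 gives the lowest number in this assay, and its steps to compound 1 and to compound 3 both lie beyond the scatter. Compound 1 and compound 3 differ in one place only: amino in place of chloro on an aromatic carbon. That change made the step of a 2.3-fold lower number from compound 3 to compound 1 (0.36 log units; beyond the scatter).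

The unmeasured compound 4 `Nc1nc(Cl)c2ncn(Cc3cccc(CCl)c3)c2n1` is related to compound 2 by the same change: amino in place of chloro on an aromatic carbon. The surroundings of the place are described in the same words in both cases, so this is the same change made on a different core. How the core of compound 2 differs from the core of compound 3 is not broken down here; the two share the same atoms, joined differently.

Within the data shown here, since the only measured example of this change lowered the number, the expectation for compound 4 is a step of similar size, a 2.1-fold lower number from compound 2 to compound 4 (0.32 log units; beyond the scatter), resting on the step from compound 3 to compound 1, a 2.3-fold lower number from compound 3 to compound 1 (0.36 log units; beyond the scatter), applied to the value of compound 2, 1690 nM. Among the measured compounds shown here, on that basis compound 4 is estimated at 800 nM in this assay, with a likely range from 300 nM to 2500 nM, the range being wide because only one example of the change, a 2.3-fold lower number from compound 3 to compound 1 (0.36 log units; beyond the scatter), is available.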

Compound 4, concentration for 50% growth inhibition: 4070 nM
The estimate for compound 4 lay 5.1-fold (0.71 log units) below the measured number, outside the stated range (above it).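

In this assay, amino in place of chloro on the aromatic carbon between two ring nitrogen atoms gave a 2.4-fold higher number from compound 2 to compound 4 (0.38 log units; beyond the scatter), so on this core the change weakened growth inhibition, whereas on the other core it strengthened it. The two results point in opposite directions, and the gap between them is larger than repeated measurements would explain: the same change on two cores in this assay, a 2.3-fold lower number (0.36 log units; beyond the scatter) from compound 3 to compound 1 and a 2.4-fold higher number (0.38 log units; beyond the scatter) from compound 2 to compound 4, 5.5-fold (0.74 log units) apart, beyond the scatter of two such steps For this series, then, a step measured on one core cannot simply be carried over to the other, since the same swap of one group for another did not give the same result on the two cores. Among these compounds, with only two pairs, however, this does not show why the cores differ, nor which direction would be more usual on further related cores.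

The compounds shown compare only chloro and amino at this place, so they leave open how a methoxy group or a methylamino group there would behave on either core. They also leave open whether the two cores would still part ways if the chloromethyl group were replaced by a hydroxymethyl group or a longer chain such as chloroethyl.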